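This account rests on a few compounds, and the source may have more. Where it says the series, first, only, none or still open, it means among the compounds named here.

Compound 3 `ClCc1cccc(Cn2cnc3c(Cl)ncnc32)c1` gives the lowest of the three values recorded so far in a functional assay on HCC 2998 cells (Homo sapiens) for cytotoxicity, read by sulforhodamine B assay, with a stated time of 48 h (a higher number here means that more compound is tolerated, a lower number that less compound is tolerated), with compound 3 giving 5490 nM. Compound 1 `ClCc1ccccc1Cn1cnc2c(Cl)nc(Cl)nc21` gives 6160 nM in this assay, a gap from compound 3 that lies within the scatter, while compound 2 `ClCc1cccc(Cn2cnc3ncnc(Cl)c32)c1` gives 40700 nM, a gap that lies beyond it. Compound 4 `ClCc1cccc(Cn2cnc3c(Cl)nc(Cl)nc32)c1` has not yet been run. It differs from compound 3 by chloro in place of hydrogen on an aromatic carbon. Among the compounds with values here, no measured pair shows this change directly, so the size of the step cannot be read from the data; compound 1, which carries two chloro groups on its core, sits close to compound 3, and no step beyond the scatter is expected. Compound 4 is therefore estimated at 5000 nM, within 2000 nM to 14000 nM, a step of a 1.1-fold lower number from compound 3 to compound 4 (0.04 log units; within the scatter).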

Compound 4, concentration lethal to 50% of the cells: 6160 nM
The estimate for compound 4 lay 1.2-fold (0.09 log units) below the measured number, within the range that was stated.
By their numbers in this assay, from the lowest: compounds 3, 1 and 4 (each within the scatter of the next); then compound 2.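

Chloro in place of hydrogen on an aromatic carbon between two ring nitrogen atoms can now be read directly: in this assay, the change gives a step within the scatter (a 1.1-fold higher number from compound 3 to compound 4 (0.05 log units; within the scatter)). Within the data shown here, no earlier pair showed this change, and here compound 3 and compound 4 cannot be told apart, so this added chloro group leaves no measurable mark on the number. Nothing available explains this result. The compounds shown leave open whether an amine or a methoxy group on this same carbon would give a number set apart from that of compound 3.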